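The compounds below may be only part of what the source reports. "The series", "measured", "known", "first", "only" and "open" are said of these compounds alone.

Of the compounds shown here, three built on one shared core have been measured in a functional assay on PC-3 cells (Homo sapiens) for cytotoxicity, read by sulforhodamine B assay; a lower number here means a stronger inhibitor of growth, a higher number a weaker inhibitor of growth. Compound 1 `COc1cccc(OC)c1OCCNCCOc1ccccc1OCc1cccc(Cl)c1` gives 5900 nM. Compound 2 `COc1cccc(OC)c1OCCNCCOc1ccccc1OCc1ccccc1C` gives 11500 nM, and compound 3 `COc1cccc(OC)c1OCCNCCOc1ccccc1OCc1ccc([N+](=O)[O-])cc1` gives 12000 nM. Among these three numbers compound 3 stands highest: against compound 2 the gap is a 1.0-fold higher number from compound 2 to compound 3 (0.02 log units; within the scatter), which sits within the scatter, and against compound 1 it is a 2.0-fold higher number from compound 1 to compound 3 (0.31 log units; beyond the scatter), a modest step that only just clears the scatter. The one thing that varies across the three is the aromatic group sitting on a saturated chain carbon bound to an oxygen on an aromatic ring.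

Compound 4 `COc1ccccc1COc1ccccc1OCCNCCOc1c(OC)cccc1OC` has not yet been measured. It differs from compound 3 at that same place: 2-methoxyphenyl in place of 4-nitrophenyl on a saturated chain carbon bound to an oxygen on an aromatic ring. The measured steps that bear on this change are the earlier swaps at the same position, a 1.9-fold higher number from compound 1 to compound 2 (0.29 log units; within the scatter) and a 2.0-fold higher number from compound 1 to compound 3 (0.31 log units; beyond the scatter), together with a 1.0-fold higher number from compound 2 to compound 3 (0.02 log units; within the scatter); none of them shifted the number by much. On that basis only a small step is expected in this assay, a 1.3-fold lower number from compound 3 to compound 4 (0.12 log units; within the scatter), with no clear direction beyond the scatter. Compound 4 is therefore estimated at 9000 nM, within a range from 4000 nM to 20000 nM.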

Compound 4, concentration for 50% growth inhibition: 8900 nM
Estimate against measurement, compound 4: 1.0-fold (0.00 log units) above; low and high end bracket the measured number.
By their numbers in this assay, from the lowest: compounds 1, 4, 2 and 3 (each within the scatter of the next, the first and the last beyond it).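

In this assay, among these compounds, 2-methoxyphenyl in place of 4-nitrophenyl gives a 1.3-fold lower number from compound 3 to compound 4 (0.13 log units; within the scatter), and 2-methoxyphenyl in place of 3-chlorophenyl gives a 1.5-fold higher number from compound 1 to compound 4 (0.18 log units; within the scatter), so a fourth aromatic group at this place also stays within the scatter of the earlier compounds. The smallest change in the set, methoxy in place of methyl on an aromatic carbon, gives a 1.3-fold lower number from compound 2 to compound 4 (0.11 log units; within the scatter), so this swap of one small group for another cannot be told apart from no change at all. Compound 4 therefore adds no new separation, and the only gap beyond the scatter remains the modest one seen earlier, a 2.0-fold higher number from compound 1 to compound 3 (0.31 log units; beyond the scatter). Nothing available here bears on what lies behind these small steps.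

From the compounds shown here alone, all four compounds carry a substituted phenyl group at this place, so it remains open whether a group of a different kind on that ring, such as an amine or a carboxylic acid, would shift the number by more. Going by these compounds, it is equally open whether a longer chain between the oxygen and the ring, or a change elsewhere in the shared core, would move the growth inhibition beyond the scatter.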